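A Bromoethyl Amide in Place of an Acrylamide

This account rests on a few compounds, and the source may have more. Where it says the series, first, only, none or still open, it means among the compounds named here.

Compound 3 `C=CC(=O)N(Cc1ccc(OC)c(O)c1)c1cc(OC)c(OC)c(OC)c1` is tested in a functional assay on KYSE-450 cells (Homo sapiens) for inhibition, read by MTT assay, with a stated time of 48 h (a lower number here means a stronger inhibitor, a higher number a weaker inhibitor), where compound 3 gives 160 nM. Among the three measured compounds it stands second highest: compound 1 `CCC/C=C/C(=O)N(Cc1ccc(OC)c(O)c1)c1cc(OC)c(OC)c(OC)c1` gives 57 nM, and compound 2 `COc1ccc(CN(C(=O)CCCCCl)c2cc(OC)c(OC)c(OC)c2)cc1O` gives 770 nM. The new compound 4 `COc1ccc(CN(C(=O)C(C)Br)c2cc(OC)c(OC)c(OC)c2)cc1O` differs from compound 3 in one place: 1-bromoethyl in place of vinyl on a carbonyl carbon. Among the measured compounds shown here, two measured steps bear on this swap, since each exchanges an unsaturated chain for a halogen-bearing saturated one: a 14-fold higher number from compound 1 to compound 2 (1.13 log units; beyond the scatter), and in the reverse direction a 4.8-fold lower number from compound 2 to compound 3 (0.68 log units; beyond the scatter). Both show a weaker inhibitor when the double bond is lost and a halogen enters, so a higher number is expected for compound 4, by a step of roughly a 3.1-fold higher number from compound 3 to compound 4 (0.49 log units; beyond the scatter). Compound 4 is therefore estimated at 500 nM, with a range of 150 nM to 1600 nM.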

Compound 4, half-maximal inhibitory concentration: 160 nM
Estimate against measurement, compound 4: 3.1-fold (0.49 log units) above; the range from low to high includes it.
By their numbers in this assay, from the lowest: compound 1; then compounds 3 and 4 (each within the scatter of the next); then compound 2.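

Swapping vinyl for 1-bromoethyl on this carbonyl carbon gives no change at the digits printed from compound 3 to compound 4 (within the scatter) in this assay, so here the loss of the double bond and the entry of a halogen cost nothing measurable. Halogen-bearing chains are not interchangeable at this position, as 1-bromoethyl in place of 4-chlorobutyl gives a 4.8-fold lower number from compound 2 to compound 4 (0.68 log units; beyond the scatter), while the longer unsaturated chain still holds an edge, with a 2.8-fold higher number from compound 1 to compound 4 (0.45 log units; beyond the scatter). No measurement shown explains these differences. Still open, on these data alone, is whether the bromine matters at all: a plain ethyl group, a 1-chloroethyl group or an amine-bearing chain on the same carbonyl carbon would help separate the halogen from the chain.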